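The compounds below may be only part of what the source reports. "The series", "measured", "known", "first", "only" and "open" are said of these compounds alone.

Of the compounds shown here, three sharing one core have been measured in an assay on isolated protein for inhibition of leukotriene B4 receptor 1 (Homo sapiens), tested at 10 uM; on this read-out higher numbers stand for more inhibition at the one concentration tested (going by the name of the read-out) and lower numbers for less inhibition. Compound 1, `CCc1cc(C(C)=O)c(O)cc1OCCCCCCC#N`, gives 103%. Compound 2, `CCc1cc(C(C)=O)c(O)cc1OCCCCCCSC`, gives 71%. Compound 3, `CCc1cc(C(C)=O)c(O)cc1OCCCCCCS(C)(=O)=O`, gives 99%, which places it second highest of the three: compared with compound 1 it lies within the scatter, and compared with compound 2 it stands clearly above, as a number 28 percentage points higher from compound 2 to compound 3 (beyond the scatter) shows. The step of a number 32 percentage points lower from compound 1 to compound 2 (beyond the scatter) is the one large movement so far, while a number 4 percentage points lower from compound 1 to compound 3 (within the scatter) stays within the scatter.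

Compound 4, `CCc1cc(C(C)=O)c(O)cc1OCCCCCn1cncn1`, has not yet been measured. Its difference from compound 3 is 1H-1,2,4-triazol-1-yl in place of (methylsulfonyl)methyl on a saturated chain carbon, five bonds along the chain from an oxygen on an aromatic ring. Among the compounds with values here, none of the measured steps swaps a chain-end group for a ring, so the closest guidance is that exchanging one chain-end group for another has so far moved this assay by a modest amount at most. The step is therefore expected to be a number 11 percentage points lower from compound 3 to compound 4 (beyond the scatter), most likely within or just beyond the scatter and more likely downward than upward. Compound 4 is estimated at 88%, between 62% and 105%.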

Compound 4, a percentage reported as inhibition, at one concentration (the size of the read-out at that concentration, not a potency): 82%
For compound 4 the middle estimate is 6 percentage points above the measured one; measured number inside the range.
By their numbers in this assay, from the lowest: compound 2; then compound 4; then compounds 3 and 1 (each within the scatter of the next).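

Placing a ring at the chain end, where the earlier compounds carried only open-chain groups, does not abolish the signal in this assay, but it does not match the best open-chain groups: the change gives a number 17 percentage points lower from compound 3 to compound 4 (beyond the scatter) and a number 21 percentage points lower from compound 1 to compound 4 (beyond the scatter). The same ring still compares well with the methylsulfanyl end group, with a number 11 percentage points higher from compound 2 to compound 4 (beyond the scatter), so it occupies a middle level among these four compounds. Nothing available explains these differences.

The group that leaves in each of these steps includes the last chain carbon, so the effect of the ring and the effect of the shorter chain remain unresolved. As far as these compounds go, how an amine, a carboxylic acid or a 1H-imidazol-1-yl ring at the chain end would compare also remains open.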